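The source may hold more compounds than are shown below. What is called first, only, known or untested is meant among the compounds shown, and "the series" means these compounds.

Two compounds of this series have so far been run in a functional assay on NCI-H460 cells (Homo sapiens) for antiproliferative activity, read by CCK-8 assay, with a stated time of 72 h, tested at 2 uM; on this read-out higher numbers stand for a stronger effect at the one concentration tested and lower numbers for a weaker effect. Compound 1 `CCCCn1cnc2c(Nc3cccc(Cl)c3)nc(NCOCc3ccc(/C=C/C(=O)Nc4ccccc4N)cc3)nc21` gives 25.7%. Compound 2 `Nc1ccccc1NC(=O)c1ccc(Cn2cnc3c(Nc4ccccc4)nc(Cl)nc32)cc1` gives 42.7%, the higher of the two numbers; its nearest neighbour on this read-out is compound 1, a number lower by a margin beyond the usual scatter. For the measured compounds named here, compound 1 and compound 2 differ in several places at once, so no single step between them is computed, and the two values are taken only as what they show.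

Compound 3 `Nc1ccccc1NC(=O)c1ccc(Cn2cnc3c(Nc4ccc(-c5ccccn5)cc4)nc(Cl)nc32)cc1` is the next member and has not yet been measured. It differs from compound 2 in one place: pyridin-2-yl in place of hydrogen on an aromatic carbon. Going by the values given here, no measured pair in the set isolates this change, so no step for it can be read off, and the expectation rests on the value of compound 2 alone.

In this assay compound 3 is expected to come out near 50%, within 30% to 72%. The expected step of a number 7.3 percentage points higher from compound 2 to compound 3 (within the scatter) is a modest increase, one that may still lie within the scatter of repeated runs.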

Compound 3, a percentage reported as inhibition, at one concentration (the size of the read-out at that concentration, not a potency): 18.1%
Estimate against measurement, compound 3: 31.9 percentage points above, and the stated range ends above it.
By their numbers in this assay, from the lowest: compounds 3 and 1 (each within the scatter of the next); then compound 2.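

In this assay, pyridin-2-yl in place of hydrogen on the aromatic carbon para to a large group gives a number 24.6 percentage points lower from compound 2 to compound 3 (beyond the scatter). For the compounds shown here, this is the first step that isolates a single place, and it shows that this position of the anilino ring does not tolerate every substituent: the change from phenyl to 4-(pyridin-2-yl)phenyl, which adds one six-membered aromatic ring with 1 hetero atom, does not hold the read-out at the level of compound 2. No measurement bearing on the reason for this step is available, so the drop stands here as an observation only.

The compounds shown leave open whether the drop belongs to this particular group or to any substituent at this position, since a single step cannot tell a fluorine, a methyl or a methoxy from an aromatic ring here. They also leave open whether a plain phenyl or a pyridin-3-yl at the same carbon would go with a similar step, and how the change reads on a full concentration curve rather than at one concentration.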